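The source may report more compounds than this note shows. Statements on the series, on what has been measured and on what is new or still open speak of the compounds shown alone.

Values in a functional assay on SW-620 cells (Homo sapiens) for antiproliferative activity, read by MTT assay, with a stated time of 72 h; a lower number here means a stronger inhibitor, a higher number a weaker inhibitor:
- Compound 1 `O=C1O[C@H]([C@@H](O)Cn2cc(-c3cccc(O)c3)nn2)C(OCc2ccccc2)=C1OCc1ccccc1`: > 100000 nM (a limit, not a number)
- Compound 2 `CC(C)(C)c1cn(C[C@H](O)[C@H]2OC(=O)C(OCc3ccccc3)=C2OCc2ccccc2)nn1`: 35800 nM
- Compound 3 `C[Si](C)(C)c1cn(C[C@H](O)[C@H]2OC(=O)C(OCc3ccccc3)=C2OCc2ccccc2)nn1`: 56000 nM

Only compound 2 and compound 3 have numbers, and these two cannot be told apart, with a 1.6-fold higher number from compound 2 to compound 3 (0.19 log units; within the scatter). The next compound to consider is compound 4 `O=C1O[C@H]([C@@H](O)Cn2cc(CCO)nn2)C(OCc2ccccc2)=C1OCc1ccccc1`. It carries 2-hydroxyethyl in place of the group of 4 heavy atoms (3 carbon, 1 silicon; no ring) of compound 3, on an aromatic carbon of the five-membered aromatic ring with 3 nitrogen (a group of 3 heavy atoms (2 carbon, 1 oxygen; no ring) in place of a group of 4 heavy atoms (3 carbon, 1 silicon; no ring), on an aromatic carbon).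

All measured steps change the group at this same carbon. Replacing 3-hydroxyphenyl with tert-butyl gives an at least 2.7-fold lower number from compound 1 to compound 2 (0.44 log units; beyond the scatter). Replacing it with the silicon-bearing group gives an at least 1.7-fold lower number from compound 1 to compound 3 (0.25 log units; that floor lies within the scatter). Going by the values given here, compound 1, the only measured compound whose group also holds a hydroxy, stands at a limit of > 100000 nM, so a drift toward a higher number is expected in this assay. The expected step is a 1.3-fold higher number from compound 3 to compound 4 (0.10 log units; within the scatter), which is small and is not expected to clear the scatter. Compound 4 is estimated at 70000 nM, with an expected range of 30000 nM to 130000 nM. A report of compound 4 as a limit alone would also be no surprise.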

Compound 4, half-maximal inhibitory concentration: > 100000 nM
Compound 4: only a limit was reported; the forecaster's own chance of this, stated with the estimate: 40%; at least 1.4-fold (0.15 log units) between middle value and limit.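

In this assay, the change to 2-hydroxyethyl gives an at least 2.7-fold higher number from compound 2 to compound 4 (0.44 log units; beyond the scatter), so a short chain at this carbon, and not only the 3-hydroxyphenyl of compound 1, can separate from tert-butyl. The comparison with the silicon-bearing group is less firm, with an at least 1.7-fold higher number from compound 3 to compound 4 (0.25 log units; that floor lies within the scatter). Among the compounds shown, the two groups that hold a hydroxy now both sit at the assay's limit, while the two groups without one have numbers, and the step between compound 1 and compound 4 cannot be read: the limit of > 100000 nM in this assay, at which 2 of the 4 values shown sit.

Going by these compounds alone, this split rests on four compounds, and no pair among them differs only by the hydroxy, so the hydroxy cannot yet be separated from the other differences between these groups. An ethyl or 2-methoxyethyl group at this carbon would bear directly on that question, while an amine, a carboxylic acid or a longer hydroxyalkyl chain would show whether other groups at this position also end at the limit or give readable numbers in this assay.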